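The source may report more compounds than this note shows. Statements on the series, on what has been measured and on what is new or still open speak of the compounds shown alone.

Measured compounds:
- compound 1, `COc1ccc(NC(=O)Nc2nc(Sc3c[nH]c4ccccc34)cc(N3CCN(Cc4ccccc4)CC3)n2)cc1`, 21400 nM
- compound 2, `Cc1cc(Cl)ccc1NC(=O)Nc1nc(NC2CC2)cc(Sc2c[nH]c3ccccc23)n1`, 9740 nM
- compound 3, `COc1ccc(NC(=O)Nc2nc(Nc3cc(OC)cc(OC)c3)cc(Sc3c[nH]c4ccccc34)n2)cc1`, 17400 nM

The three compounds were tested in a functional assay on HepG2 cells (Homo sapiens) for inhibition, with a stated time of 72 h; a lower number here means a stronger inhibitor, a higher number a weaker inhibitor. Compound 2 gives the lowest of the three numbers, 9740 nM. Its nearest neighbour is compound 3 at 17400 nM, a gap that stays within the scatter of repeated measurements, so the two cannot be ordered. Compound 1 at 21400 nM lies further off, beyond the scatter, so compound 2 is the stronger inhibitor of that pair. Going by the values given here, the three compounds differ from one another in more than one place, so no single step between them can be read off.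

Compound 4, `O=C(Nc1ccccc1)Nc1nc(NC2CC2)cc(Sc2c[nH]c3ccccc23)n1`, has not yet been measured in this assay. It is derived from compound 2 by one change:

phenyl in place of 4-chloro-2-methylphenyl on an amide-type nitrogen

Among the compounds with values here, nothing among the measured compounds isolates this exact change. With the chlorine and the methyl group gone from the aryl urea, a modest weakening is expected, of a size close to the edge of the scatter, rather than a gain. For compound 4 the expected value is 16000 nM, within a range from 6000 nM to 42000 nM, which corresponds to an expected step of a 1.6-fold higher number from compound 2 to compound 4 (0.22 log units; within the scatter).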

Compound 4, half-maximal inhibitory concentration: 14300 nM
Estimate against measurement, compound 4: 1.1-fold (0.05 log units) above, within the range that was stated.
By their numbers in this assay, from the lowest: compounds 2, 4, 3 and 1 (each within the scatter of the next, the first and the last beyond it).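

This is the only pair shown that differs in one place, and it isolates the aryl group on the amide-type nitrogen, with the cyclopropylamino side of the core held constant. In this assay the exchange of 4-chloro-2-methylphenyl for phenyl gives a 1.5-fold higher number from compound 2 to compound 4 (0.17 log units; within the scatter) and so the two compounds cannot be ordered: removing the chlorine and the methyl group together leaves no readable difference at this position. Nothing measured on these groups is available to account for this result.

The compounds shown do not separate the chlorine from the methyl group, as neither appears alone on the phenyl ring of this urea, so two opposing contributions cannot be distinguished from two negligible ones. On these data alone, it also remains open whether a carboxylic acid or a dimethylamino group on that phenyl ring, or a pyridine ring in its place, would produce a step beyond the scatter at this position.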